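A few compounds are considered here, and "the series" means these few. Any claim that something is new, unique, unknown or untested is made for them only; others in the source may bear on it.

Series notes. Compound 1 `CCN(CC)CCn1c(N)c(-c2nc3ccccc3n2C)c2nc(C#N)c(C#N)nc21`, compound 2 `CN(C)CCCn1c(N)c(-c2nc3ccccc3n2C)c2nc(C#N)c(C#N)nc21` and compound 3 `CCN(CC)CCCn1c(N)c(-c2nc3ccccc3n2C)c2nc(C#N)c(C#N)nc21` have been measured in a functional assay on HL-60 cells (Homo sapiens) for antiproliferative activity, read by MTT assay, with a stated time of 48 h; on this read-out higher numbers stand for weaker inhibition and lower numbers for stronger inhibition; compound 4 `CN(C)CCCCn1c(N)c(-c2nc3ccccc3n2C)c2nc(C#N)c(C#N)nc21` has not. In this assay compound 1 gives 8800 nM, compound 2 gives 2120 nM and compound 3 gives 2810 nM. The change (dimethylamino)methyl in place of diethylamino on a saturated chain carbon, two bonds along the chain from an aromatic nitrogen produced a 4.2-fold lower number from compound 1 to compound 2 (0.62 log units; beyond the scatter). The same kind of change, ((dimethylamino)methyl in place of diethylamino on a saturated chain carbon, three bonds along the chain from an aromatic nitrogen), leads to compound 4, but the cores differ by (diethylamino)methyl in place of diethylamino on a saturated chain carbon, two bonds along the chain from an aromatic nitrogen, so the change now sits three bonds along the chain from an aromatic nitrogen rather than two. Lengthening the chain alone gave a 1.3-fold higher number from compound 2 to compound 3 (0.12 log units; within the scatter), within the scatter. For compound 4 a smaller step than the earlier one, a 1.9-fold lower number from compound 3 to compound 4 (0.27 log units; within the scatter), is expected, because compound 3 already stands at 2810 nM. Compound 4 is estimated at 1500 nM, expected between 500 nM and 4500 nM.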

Compound 4, half-maximal inhibitory concentration: 740 nM
Compound 4: the middle estimate sits 2.0-fold (0.31 log units) above what was measured; the range from low to high includes it.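

In this assay, (dimethylamino)methyl in place of diethylamino gives a 3.8-fold lower number from compound 3 to compound 4 (0.58 log units; beyond the scatter), and this step matches the earlier one on the shorter chain: the same change on two cores in this assay, a 4.2-fold lower number (0.62 log units; beyond the scatter) from compound 1 to compound 2 and a 3.8-fold lower number (0.58 log units; beyond the scatter) from compound 3 to compound 4, 1.1-fold (0.04 log units) apart, within the scatter of two such steps. Compound 4 also has the lowest number of the series, with a 2.9-fold lower number from compound 2 to compound 4 (0.46 log units; beyond the scatter) and a 12-fold lower number from compound 1 to compound 4 (1.08 log units; beyond the scatter). The match rests on a single pair of steps in one cell line; it shows that the change carries over between these two cores, but not that it would hold on other cores or in other cells, and it gives no reason for the step.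

Still open, on these data alone, is whether a pyrrolidine or a morpholine at the chain end would match the dimethylamino group. Also open, as far as these compounds go, is whether a chain longer than 4-(dimethylamino)butyl would lower the number further.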